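The compounds below may be only part of what the source reports. "The series", "measured", "known", "first", "only" and "open" are said of these compounds alone.

Compound 1, `COC(C)(C)CCCC(C)C/C=C/C(C)=C/C(=O)OCCC(C)C`, gives the higher of the two numbers in a physicochemical assay for lipophilicity; on this read-out lower numbers stand for lower lipophilicity and higher numbers for higher lipophilicity: compound 1 measures 7.03. The other measured compound, compound 2, `COC(C)(C)C(O)CCC(C)C/C=C/C(C)=C/C(=O)OC(C)C`, gives 3.86 in this assay, a gap well beyond the scatter. Compound 3, `CCN(CC)C(=O)/C=C(C)/C=C/CC(C)CCCC(C)(C)OC`, is reached from compound 1 by one change: diethylamino in place of isopentyloxy on a carbonyl carbon. No step of this kind has been measured among these compounds. A fall beyond the scatter is expected, so that the step of a number 1.73 log units lower from compound 1 to compound 3 (beyond the scatter) is estimated to read downward. For compound 3 the expected value in this assay is 5.3, within 4.5 to 6.1.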

Compound 3, partition coefficient: 4.82
Estimate against measurement, compound 3: 0.48 log units above; measured number inside the range.
By their numbers in this assay, from the lowest: compound 2; then compound 3; then compound 1.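

With the shared core unchanged, diethylamino in place of isopentyloxy on a carbonyl carbon gives a number 2.21 log units lower from compound 1 to compound 3 (beyond the scatter) in this assay. This is the first single-place change shown at this position, since compound 2 differs from compound 1 in more than one place, and it shows that this read-out responds strongly to the group held there. No measured evidence bears on the reason for this step. The compounds shown leave open how dimethylamino, pyrrolidinyl or a carboxylic acid at this carbonyl carbon would read, and whether diethylamino would give a similar step on the core of compound 2.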